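Working notes: from compound 2 to compound 3

A few compounds are considered here, and "the series" means these few. Any claim that something is new, unique, unknown or untested is made for them only; others in the source may bear on it.

Measured so far:
compound 1 `COc1cc(Cl)cc(-c2nn(-c3cccc(NC(=O)Nc4ccc(Cl)c(Cl)c4)c3)cc2-c2ccncc2)c1`: 96%
compound 2 `COc1cc(Cl)cc(-c2nn(-c3cccc(NC(=O)Nc4cccc(C(F)(F)F)c4)c3)cc2-c2ccncc2)c1`: 96%

In a functional assay on LOX IMVI cells (Homo sapiens) for inhibition, read by sulforhodamine B assay, with a stated time of 48 h, tested at 0.01 uM (on this read-out higher numbers stand for a weaker effect at the one concentration tested and lower numbers for a stronger effect), compound 2 gives 96%, level with compound 1 at the digits shown. Among the compounds with values here, the single measured step, no change at the digits printed from compound 1 to compound 2 (within the scatter), swapped one group on the amide-type nitrogen with no change beyond the scatter. Compound 3 `COc1cc(Cl)cc(-c2nn(-c3cccc(NC(=O)c4cccc(C(F)(F)F)c4)c3)cc2-c2ccncc2)c1` differs from compound 2 by 3-(trifluoromethyl)phenyl in place of (3-(trifluoromethyl)phenyl)amino on a carbonyl carbon. Within the data shown here, no measured step touches the carbonyl carbon itself, so that step bears only loosely here; still, with compound 2 at 96% and the step of no change at the digits printed from compound 1 to compound 2 (within the scatter) flat, the expected step of a number 1 percentage points lower from compound 2 to compound 3 (within the scatter) is none beyond the scatter. Compound 3 is estimated at 95%, range 84% to 102%.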

Compound 3, a percentage reported as activity, at one concentration (the size of the read-out at that concentration, not a potency): 100%
Compound 3: middle estimate off by 5 percentage points, on the low side; measured number inside the range.
By their numbers in this assay, from the lowest: compounds 1, 2 and 3 (each within the scatter of the next).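

In this assay, within the data shown here, the change reaches the link itself for the first time: 3-(trifluoromethyl)phenyl in place of (3-(trifluoromethyl)phenyl)amino on a carbonyl carbon gives a number 4 percentage points higher from compound 2 to compound 3 (within the scatter), and the comparison with the dichlorophenyl compound gives a number 4 percentage points higher from compound 1 to compound 3 (within the scatter). At this one concentration, therefore, the amino group on the carbonyl carbon can be lost without a shift beyond the scatter. Nothing available explains this flat result.

Still open, as far as these compounds go, is whether a smaller group on the carbonyl carbon, such as methyl, or a carboxylic acid on the aromatic ring, would shift the read-out beyond the scatter. A single concentration also leaves open whether the effect of any of the three compounds would be stronger or weaker at other concentrations.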